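Swapping a dimethylphenyl for a methoxyphenyl

A few compounds are considered here, and "the series" means these few. Any claim that something is new, unique, unknown or untested is made for them only; others in the source may bear on it.

Values measured so far in a functional assay on M21 cells (Homo sapiens) for antiproliferative activity, read by sulforhodamine B assay, with a stated time of 48 h (a higher number here means a weaker inhibitor, a lower number a stronger inhibitor), are these:

Compound 1 `CCCCc1ccc(NS(=O)(=O)c2ccc(N3CCNC3=O)cc2)cc1` gives 450 nM
Compound 2 `COc1ccc(NS(=O)(=O)c2ccc(N3CCNC3=O)cc2)cc1OC` gives 340 nM
Compound 3 `Cc1cccc(NS(=O)(=O)c2ccc(N3CCNC3=O)cc2)c1C` gives 110 nM

Compound 3, with 110 nM as its value, has the lowest number of the three. Its gaps to compound 1 and compound 2 both lie beyond the usual scatter of repeat measurements, so compound 3 is the strongest inhibitor in this small set.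

Compound 4 `COc1ccc(NS(=O)(=O)c2ccc(N3CCNC3=O)cc2)cc1` has not been measured yet. It keeps the shared core of compound 3 and differs in one place, with 4-methoxyphenyl in place of 2,3-dimethylphenyl on a sulfonamide nitrogen. The counted difference is 4-methoxyphenyl in place of 2,3-dimethylphenyl on a sulfonamide nitrogen and nothing else changes.

Within the data shown here, no two measured compounds differ in only one place, so no measured step can guide this estimate directly. The best evidence is indirect. Compound 2 also carries methoxy and gives 340 nM in this assay for a number well above that of compound 3. A weaker inhibitor is therefore expected, with an estimated step of a 3.6-fold higher number from compound 3 to compound 4 (0.56 log units; beyond the scatter) and a size probably beyond the scatter. Compound 4 is expected to give about 400 nM with an estimated range from 140 nM to 1100 nM when it is tested.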

Compound 4, half-maximal inhibitory concentration: 580 nM
Compound 4: middle estimate off by 1.5-fold (0.16 log units), on the low side, within the range that was stated.
By their numbers in this assay, from the lowest: compound 3; then compounds 2, 1 and 4 (each within the scatter of the next).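

With the shared core held fixed, changing the group on the sulfonamide nitrogen from 2,3-dimethylphenyl to 4-methoxyphenyl gives a 5.3-fold higher number from compound 3 to compound 4 (0.72 log units; beyond the scatter) in this assay, a step beyond the scatter, which shows that this position responds to the choice of aromatic group. The other two single changes do not separate from repeat-measurement noise: hydrogen in place of methoxy gives a 1.7-fold higher number from compound 2 to compound 4 (0.23 log units; within the scatter), and methoxy in place of butyl gives a 1.3-fold higher number from compound 1 to compound 4 (0.11 log units; within the scatter), both within the scatter, so neither change has a measurable effect in this assay. No measurement shown here bears on the cause of the larger step.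

It remains open which feature of 2,3-dimethylphenyl accounts for the difference, and a phenyl ring carrying a single methyl group would be a direct way to divide that change into smaller steps. It is also unknown how this position would respond to a ring bearing an amine or a carboxylic acid.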